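The source may hold more compounds than are shown below. What is called first, only, known or untested is meant among the compounds shown, and "the series" means these compounds.

Measured so far:
compound 1 `O=C(/C=C/c1ccc(C(F)(F)F)cc1)c1cccc(O)c1` gives in this assay only a limit, > 10000 nM.
compound 2 `O=C(/C=C/c1ccc(C(F)(F)F)cc1)c1ccc(O)cc1` gives only a limit, > 10000 nM.
compound 3 `O=C(/C=C/c1cccc(OC(F)(F)F)c1)c1cccc(O)c1` gives only a limit, > 10000 nM.

The three compounds were tested in a functional assay on RAW264.7 cells (Mus musculus) for inhibition, read by fluorescence, with stated times of 1 h, 24 h and 30 min; on this read-out higher numbers stand for weaker inhibition and lower numbers for stronger inhibition. For compound 1 the read-out is a limit of the assay, not a number. The same holds for compound 2. Compound 2 differs from compound 1 by 4-hydroxyphenyl in place of 3-hydroxyphenyl on a carbonyl carbon, and the step that the two limits leave unreadable from compound 1 to compound 2 cannot be sized because both values sit at the limit of > 10000 nM in this assay, at which 3 of the 3 values shown sit. For compound 3 the read-out is again a limit. How the core of compound 3 differs from the core of compound 1 is not broken down here.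

Compound 4 `O=C(/C=C/c1cccc(OC(F)(F)F)c1)c1ccc(O)cc1` has not yet been measured in this assay. It differs from compound 3 by 4-hydroxyphenyl in place of 3-hydroxyphenyl on a carbonyl carbon, the same change as that from compound 1 to compound 2, made at a place described in the same words. Compound 4 is therefore expected to show the step that the limit leaves unreadable from compound 3 to compound 4, which rests on the finding that compound 1, compound 2 and compound 3 all sit at the limit of > 10000 nM in this assay, at which 3 of the 3 values shown sit. Compound 4 is estimated at 12000 nM, between 5000 nM and 30000 nM.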

Compound 4, half-maximal inhibitory concentration: > 10000 nM
Compound 4: only a limit was reported; the forecaster's own chance of this, stated with the estimate: 80%; the middle value lies beyond the limit too.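

Compound 4 also gives only a limit, > 10000 nM. No step from compound 3 to compound 4 can be read, because both compounds sit at the same limit: the limit of > 10000 nM in this assay, at which 4 of the 4 values shown sit.

The compounds shown leave open whether 4-hydroxyphenyl and 3-hydroxyphenyl differ at all in this assay, and what change to the shared core would give a readable value.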